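The source may report more compounds than this note shows. Statements on the series, on what has been measured and on what is new or still open speak of the compounds shown alone.

Of the compounds shown here, three of one shared core have been measured in an assay on cells for inhibition of sodium- and chloride-dependent glycine transporter 1 (Homo sapiens); a higher number here means that more compound is needed for the effect, a lower number that less compound is needed. Compound 1 `COc1cc(C(F)(F)F)cc(C(F)(F)F)c1C(=O)NC1(c2ccccc2)CCCN(C2CCCC2)C1` gives 270 nM. Compound 2 `COc1cc(C(F)(F)F)cc(C(F)(F)F)c1C(=O)NC1(c2ccccc2)CCCN(C(C)=O)C1` reaches only the limit of the assay, > 10000 nM, so that value is a limit and not a number. The change from compound 1 to compound 2 an at least 37-fold higher number from compound 1 to compound 2 (1.56 log units; beyond the scatter) therefore produces a large rise in this assay, sitting at the limit of > 10000 nM in this assay, at which 1 of the 3 values shown sits. Compound 3 `COc1cc(C(F)(F)F)ccc1C(=O)NC1(c2ccccc2)CCCN(C)C1` gives 4800 nM, the highest of the two numbers shown; compound 1 sits well below it.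

Compound 4 `CN1CCCC(NC(=O)c2ccc(C(F)(F)F)cc2F)(c2ccccc2)C1` differs from compound 3 in a single place: fluoro in place of methoxy on an aromatic carbon. Among the compounds with values here, the one measured step concerns the amine nitrogen in the ring, not the aromatic ring, so no measured step bears directly on this change. In this assay the expected step from compound 3 to compound 4 is a 1.1-fold lower number from compound 3 to compound 4 (0.03 log units; within the scatter), not beyond the usual scatter in either direction. Compound 4 is therefore estimated at 4500 nM, with a range from 1500 nM to 12000 nM.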

Compound 4, half-maximal effective concentration: 9900 nM
The estimate for compound 4 lay 2.2-fold (0.34 log units) below the measured number, and the stated range covers the measured number.
By their numbers in this assay, from the lowest: compound 1; then compound 3; then compound 4. At a limit, above all of these: compound 2.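

Within the data shown here, this is the first step that reads the aromatic ring itself rather than the amine nitrogen in the ring: in this assay, fluoro in place of methoxy on an aromatic carbon gives a 2.1-fold higher number from compound 3 to compound 4 (0.31 log units; beyond the scatter). The step is modest but beyond the scatter, so this carbon, ortho to a large group and meta to a trifluoromethyl group, does respond to what sits on it, and the methoxy can leave without the effect being lost altogether. Nothing measured here accounts for the direction or size of this step.

Going by these compounds, this single pair carries a methyl group on the ring nitrogen, so whether the step would hold with the cyclopentyl group of compound 1 remains open. Also open, on these data alone, is what a chlorine, a hydroxyl group or a longer ethoxy chain would do on this same carbon.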